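A Chloro Group on the Fused Ring of Compound 1

The source may report more compounds than this note shows. Statements on the series, on what has been measured and on what is new or still open speak of the compounds shown alone.

Measured compounds:
compound 1 `O=C(CCCc1ccccc1)Nc1nc2ccccc2c(=O)s1` gives 229 nM in an assay on membranes from brain for displacement of a labelled ligand from adenosine receptor A1 (Rattus norvegicus), read by scintillation counting, with a stated time of 90 min; a higher number here means a weaker inhibitor, a lower number a stronger inhibitor
compound 2 `O=C(CCc1ccccc1F)Nc1nc2ccccc2c(=O)s1` gives only the limit > 10000 nM in this assay

Going by the values given here, compound 1 is the only compound with a real number in this assay. For compound 2 the result is a limit of the assay, not a number, namely (the limit of > 10000 nM in this assay, at which 1 of the 2 values shown sits). Among the compounds with values here, the one step measured so far is large: an at least 43-fold higher number from compound 1 to compound 2 (1.64 log units; beyond the scatter). That step changes the chain and the phenyl group on the amide side of the molecule and leaves the shared core untouched.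

Compound 3 `O=C(CCCc1ccccc1)Nc1nc2cc(Cl)ccc2c(=O)s1` keeps the whole amide side of compound 1 and differs only on the core: chloro in place of hydrogen on an aromatic carbon. The measured step from compound 1 to compound 2 does not touch this part of the molecule, so it gives no direct guide to the size or direction of the change. With nothing measured on the core, the plain expectation is a step that stays within the scatter, a 1.0-fold lower number from compound 1 to compound 3 (0.02 log units; within the scatter). Compound 3 is therefore estimated at 220 nM, with a range from 60 nM to 800 nM.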

Compound 3, inhibition constant: 64.4 nM
Compound 3: middle estimate off by 3.4-fold (0.53 log units), on the high side; the measured number falls inside the stated range.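

The core is not a silent part of the molecule. With the whole amide side kept, adding one chlorine atom gives in this assay a 3.6-fold lower number from compound 1 to compound 3 (0.55 log units; beyond the scatter), a modest change but the first measured on the core, and it points towards a stronger inhibitor. This carbon, meta to a fused ring and para to a fused ring, therefore accepts a chloro group without any loss in this binding measurement, and nothing shown here explains why the number falls.

On these data alone, the result rests on a single substitution, so it remains open whether the lower number is particular to chloro or would also appear with a fluoro group, a methyl group or an amine on the same carbon. As far as these compounds go, it is equally open whether a chloro group on another aromatic carbon of the core would give a step of similar size and direction, and whether this step would hold with a longer chain on the amide side.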